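The compounds below may be only part of what the source reports. "The series", "measured", "known", "first", "only" and "open" are said of these compounds alone.

Measured compounds in an ADME assay on MT4 cells (Homo sapiens) for cytotoxicity, read by MTT assay; a lower number here means that less compound is tolerated, a higher number that more compound is tolerated:
- compound 1, `O=c1cc(Cc2c(F)cccc2F)nc(Sc2ccccc2)[nH]1`: > 76000 nM
- compound 2, `O=c1cc(Cc2c(F)cccc2F)nc(SCc2ccccc2)[nH]1`: > 73000 nM

Compound 1 gives > 76000 nM in this assay, which is a limit of the assay and not a number. Compound 2 gives > 73000 nM in this assay, again a limit rather than a number. The step from compound 1 to compound 2, benzyl in place of phenyl on a sulfur, is a step that the two limits leave unreadable from compound 1 to compound 2. Compound 2 therefore stands only at a limit; of the two values shown, one sits at the limit of > 73000 nM in this assay, at which 1 of the 2 values shown sits, and the other at the limit of > 76000 nM in this assay, at which 1 of the 2 values shown sits, so no number places compound 2 anywhere within the measurable range.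

Compound 3, `O=c1cc(Cc2c(F)cccc2F)nc(SCCCc2ccccc2)[nH]1`, is not yet measured. Relative to compound 2 the change is phenethyl in place of phenyl on a saturated chain carbon bound to a sulfur. Within the data shown here, the only measured step that bears on it, from compound 1 to compound 2, is unreadable between the two limits, so it gives no size and no direction in this assay. With both measured values at limits, the expectation for compound 3 is a further limit rather than a step beyond the scatter, and the step to it is estimated as a step that the limit leaves unreadable from compound 2 to compound 3. Compound 3 is estimated at 80000 nM, within 30000 nM to 200000 nM.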

Compound 3, half-maximal cytotoxic concentration: 32000 nM
Compound 3: the middle estimate sits 2.5-fold (0.40 log units) above what was measured; measured number inside the range.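

In this assay compound 3 gives 32000 nM, a number inside the measurable range, so the group on the sulfur is now seen to affect how much compound is tolerated. Among these compounds, the change, phenethyl in place of phenyl on a saturated chain carbon bound to a sulfur, is an at least 2.2-fold lower number from compound 2 to compound 3 (0.35 log units; beyond the scatter), and it is the only readable step, since the step between the two earlier compounds cannot be read. Its size is only a lower bound, as the starting value of compound 2 is a limit: the limit of > 73000 nM in this assay, at which 1 of the 3 values shown sits.

Going by these compounds, with a single number in the set, it stays open whether the tolerated concentration falls further as the chain on the sulfur grows, and a longer chain would be the direct test of that. Also open, on these data alone, is how an amine or a carboxylic acid on that chain would read in this assay, and so whether the lower number goes with the chain itself or with the phenyl ring carried on it.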